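Shortening the phenethylsulfanyl chain of a weak inhibitor

This account rests on a few compounds, and the source may have more. Where it says the series, first, only, none or still open, it means among the compounds named here.

Of the compounds shown here, three sharing one core have been tested in a functional assay on BGC-823 cells (Homo sapiens) for inhibition, read by MTT assay, with a stated time of 72 h (a lower number here means a stronger inhibitor, a higher number a weaker inhibitor), and only one of them gives a number. Compound 1 `C[C@@H]1CCN(c2cc(-c3ccccc3)nc3ncnn23)C[C@@H]1N(C)c1ncnc2[nH]ccc12` reaches only a limit of the assay at > 100000 nM and yields no number. Compound 2 `Cc1nc2nc(SCc3ccc(Cl)cc3)nn2c(N2CC[C@@H](C)[C@@H](N(C)c3ncnc4[nH]ccc34)C2)c1C` likewise gives only the limit > 100000 nM and no number. Compound 3 `Cc1cc(N2CC[C@@H](C)[C@@H](N(C)c3ncnc4[nH]ccc34)C2)n2nc(SCCc3ccccc3)nc2n1` gives 28000 nM and is the only one of the three with a true measured value.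

Compound 4 `CCCSc1nc2nc(C)cc(N3CC[C@@H](C)[C@@H](N(C)c4ncnc5[nH]ccc45)C3)n2n1` follows from compound 3 by the change methyl in place of phenyl on a saturated chain carbon, two bonds along the chain from a sulfur with methyl in place of phenyl on a saturated chain carbon, two bonds along the chain from a sulfur, so that phenethylsulfanyl becomes propylsulfanyl. Among the measured compounds shown here, no step between measured compounds is available to size this change. In this assay a modest loss is expected, because compound 3 at 28000 nM is the lone number to start from. A result at the limit of > 100000 nM in this assay, at which 2 of the 3 values shown sit, is also expected to remain a real possibility and would give no number. The estimated move is a 2.3-fold higher number from compound 3 to compound 4 (0.37 log units; beyond the scatter) and it points towards weaker inhibition. The estimated value for compound 4 is 65000 nM with an expected range between 22000 nM and 130000 nM on this reasoning.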

Compound 4, half-maximal inhibitory concentration: 51200 nM
Compound 4: the middle estimate sits 1.3-fold (0.10 log units) above what was measured; the measured number falls inside the stated range.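

In this assay, among the compounds shown here, the change from phenethylsulfanyl to propylsulfanyl gives a 1.8-fold higher number from compound 3 to compound 4 (0.26 log units; within the scatter), the first step that can be read at all. At this place, on a saturated chain carbon, two bonds along the chain from a sulfur, a phenyl of six heavy atoms and a methyl of one heavy atom therefore cannot be told apart by this read-out, and the aromatic ring at the end of the chain is not needed for a true number to appear. Compound 3 and compound 4 now both give true numbers, whereas compound 1 and compound 2 each remain at a limit of the assay: the limit of > 100000 nM in this assay, at which 2 of the 4 values shown sit.

The compounds shown leave open whether an amine or a carboxylic acid at the end of the chain, or a chain longer than phenethyl, would produce a step beyond the scatter. For the compounds shown here, they also leave open what the sulfur contributes, as no step here replaces it with an oxygen or a methylene while keeping the rest of compound 4 unchanged.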